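Pyrimidinyl for pyridinyl on the thioether side chain

A few compounds are considered here, and "the series" means these few. Any claim that something is new, unique, unknown or untested is made for them only; others in the source may bear on it.

Measured compounds:
compound 1 `CC(Sc1nc2c(cnn2C)c(=O)n1-c1ccccc1)c1cccnc1`: 95%
compound 2 `CC(Sc1nc2c(cnn2C)c(=O)n1-c1ccc(C#N)cc1)c1ccccc1`: "active" (no number reported)

Within the data shown here, in an assay on PEO1 cells for inhibition of Retinaldehyde dehydrogenase 3 (Homo sapiens), read by flow cytometry, with a stated time of 30 min, tested at 1 uM (a higher number here means more inhibition at the concentration tested (going by the name of the read-out), a lower number less inhibition), compound 1 gives 95%, the only number. Among the measured compounds shown here, compound 2 is reported only as "active" (no number reported), with no figure attached, so no step between measured compounds can be read, and compound 1 stands alone at a high level of inhibition.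

Compound 3 `CC(Sc1nc2c(cnn2C)c(=O)n1-c1ccccc1)c1cncnc1` differs from compound 1 by pyrimidin-5-yl in place of pyridin-3-yl on a saturated chain carbon bound to a saturated chain carbon and a sulfur. The shared core and the thioether side chain are kept.

For the measured compounds named here, no measured pair fixes the size of such a change, so the expectation for compound 3 rests on compound 1 alone. The step of a number 10 percentage points lower from compound 1 to compound 3 (within the scatter) is expected to be small, downward or none beyond the scatter. Compound 3 is expected to give 85% in this assay, within 60% to 98%.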

Compound 3, a percentage reported as inhibition, at one concentration (the size of the read-out at that concentration, not a potency): 39%
The estimate for compound 3 lay 46 percentage points above the measured number, outside the stated range (below it).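

In this assay, the ring on a saturated chain carbon bound to a saturated chain carbon and a sulfur proves to be a sensitive place: pyrimidin-5-yl in place of pyridin-3-yl, with the core and the rest of the thioether side chain unchanged, comes with a number 56 percentage points lower from compound 1 to compound 3 (beyond the scatter). The high inhibition of compound 1 therefore does not carry over to a close aromatic analogue, and the second ring nitrogen alone separates it from compound 3, which gives 39% at the same concentration. Nothing available on these compounds accounts for the size of this step.

Compound 2 carries no number, so steps involving it cannot be read. The compounds shown leave open whether pyridin-4-yl, or a pyridin-3-yl ring bearing an amine or a carboxylic acid, would hold inhibition at the level of compound 1 or fall towards that of compound 3.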